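From a Carboxyethyl Side Chain Back to Isopropyl

The compounds below may be only part of what the source reports. "The series", "measured", "known", "first", "only" and "open" are said of these compounds alone.

Going by the values given here, in a functional assay on the whole organism (Tail, strain ICR) with Mus musculus as the target, in the tail flick test, with a stated time of 150 min, at a dose of 25 umol/kg by the oral route (a higher number here means a stronger effect of the compound at the dose given, a lower number a weaker effect), compound 3 `O=C(O)CC[C@H](NC(=O)CN(c1nc(Cl)nc2[nH]cnc12)C1CC1)C(=O)O` gives 29.5%, the highest of the three numbers measured so far. Compound 2 `O=C(CN(c1nc(Cl)nc2[nH]cnc12)C1CC1)N[C@@H](CO)C(=O)O` gives 18.8%, and compound 1 `CC[C@H](C)[C@H](NC(=O)CN(c1nc(Cl)nc2[nH]cnc12)C1CC1)C(=O)O` gives 6.71%; both steps up to compound 3, a number 10.7 percentage points higher from compound 2 to compound 3 (beyond the scatter) and a number 22.8 percentage points higher from compound 1 to compound 3 (beyond the scatter), lie beyond the scatter. Compound 4 `CC(C)[C@H](NC(=O)CN(c1nc(Cl)nc2[nH]cnc12)C1CC1)C(=O)O` differs from compound 3 in one place: isopropyl in place of 2-carboxyethyl on a saturated chain carbon bound to an amide-type nitrogen and a carbonyl carbon. The isopropyl of compound 4 is close in shape to the sec-butyl of compound 1, so the step of a number 22.8 percentage points higher from compound 1 to compound 3 (beyond the scatter), read in reverse, bears most directly on this change. A drop of roughly that size is therefore expected in this assay, a number 19.5 percentage points lower from compound 3 to compound 4 (beyond the scatter). Compound 4 is expected to give about 10%, within a range from 2% to 22%.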

Compound 4, a percentage reported as activity, at one dose (the size of the read-out at that dose, not a potency): 7.86%
Beside the measured number, compound 4's estimate is 2.1 percentage points above it, and the stated range covers the measured number.
By their numbers in this assay, from the lowest: compounds 1 and 4 (each within the scatter of the next); then compound 2; then compound 3.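

In this assay, isopropyl on this saturated chain carbon falls clearly short of 2-carboxyethyl (a number 21.6 percentage points lower from compound 3 to compound 4 (beyond the scatter)) and of hydroxymethyl (a number 10.9 percentage points lower from compound 2 to compound 4 (beyond the scatter)). Isopropyl and sec-butyl cannot be told apart here (a number 1.2 percentage points higher from compound 1 to compound 4 (within the scatter)), so a small branching difference in a chain without oxygen does not separate these two compounds. Across these four compounds, the two side chains containing oxygen give the higher numbers. Nothing measured here explains this order. From the compounds shown here alone, whether an amine such as 4-aminobutyl, or a longer carboxylic acid chain, would match 2-carboxyethyl remains open.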